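A few compounds are considered here, and "the series" means these few. Any claim that something is new, unique, unknown or untested is made for them only; others in the source may bear on it.

Measured compounds:
- compound 1 `CCCCC(=O)Nc1ccc(N2CCN(c3ccc(OC[C@@H]4CO[C@@](Cn5cncn5)(c5ccc(Cl)cc5Cl)O4)cc3)CC2)cc1`, which in a functional assay on A549 cells (Homo sapiens) for inhibition, read by MTT assay, with a stated time of 48 h (a lower number here means a stronger inhibitor, a higher number a weaker inhibitor), gives 5340 nM
- compound 2 `O=C(Nc1ccc(N2CCN(c3ccc(OC[C@@H]4CO[C@@](Cn5cncn5)(c5ccc(Cl)cc5Cl)O4)cc3)CC2)cc1)C(/C=C/Cl)C/C=C/C(F)(F)F`, which in this assay gives 3830 nM

Compound 2 holds the lowest of the two numbers in this assay, yet its nearest neighbour is compound 1, and the pair lie within the scatter of each other, so no order between them can be read. Among the compounds with values here, the one step that differs in a single place, a 1.4-fold lower number from compound 1 to compound 2 (0.14 log units; within the scatter), exchanges the group on the carbonyl carbon of the amide and stays within the scatter.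

Compound 3 `O=C(Nc1ccc(N2CCN(c3ccc(OC[C@@H]4CO[C@@](Cn5cncn5)(c5ccc(Cl)cc5Cl)O4)cc3)CC2)cc1)c1ccco1` is the next member of the series. It differs from compound 2 by furan-2-yl in place of 1-(2-chloroethenyl)-5,5,5-trifluoropent-3-en-1-yl on a carbonyl carbon. Within the data shown here, the only comparable step, the one from compound 1 to compound 2, changed the same carbonyl substituent and produced nothing beyond the scatter, so the expectation for compound 3 in this assay is a step of about a 1.0-fold higher number from compound 2 to compound 3 (0.02 log units; within the scatter), that is, none beyond the scatter. The estimate for compound 3 in this assay is therefore 4000 nM, with a range from 1500 nM to 11000 nM.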

Compound 3, half-maximal inhibitory concentration: 10500 nM
Beside the measured number, compound 3's estimate is 2.6-fold (0.42 log units) below it; the measured number falls inside the stated range.
By their numbers in this assay, from the lowest: compounds 2, 1 and 3 (each within the scatter of the next, the first and the last beyond it).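

In this assay, the group on the carbonyl carbon of the amide now gives a step beyond the scatter, though only a modest one: the change to furan-2-yl from 1-(2-chloroethenyl)-5,5,5-trifluoropent-3-en-1-yl gives a 2.7-fold higher number from compound 2 to compound 3 (0.44 log units; beyond the scatter) and so shows that this position is not wholly indifferent to its substituent. The same ring in place of butyl gives a 2.0-fold higher number from compound 1 to compound 3 (0.29 log units; within the scatter) and stays within the scatter, so furan-2-yl cannot be said to differ from every open chain here, and the whole signal rests on a single pair of compounds. Nothing in the material shown explains the step at this position.

The three compounds do not settle whether the step follows from the presence of an aromatic ring, from the loss of the chlorine and fluorine atoms, or from the particular chain that left. A phenyl or thiophen-2-yl group on the same carbonyl carbon, or a shorter chain such as propyl, would be needed to separate these readings.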